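The compounds below may be only part of what the source reports. "The series", "measured", "known", "first", "only" and "open" are said of these compounds alone.

Compound 1 `Cc1cc(NC(=O)Nc2ccc(C)c(Cl)c2)c2ccccc2n1`: > 25000 nM
Compound 2 `Cc1cc(NC(=O)Nc2ccc(Cl)c(Cl)c2)c2ccccc2n1`: 23000 nM

In an ADME assay on BJ cells (Homo sapiens) for cytotoxicity, with a stated time of 72 h (a higher number here means that more compound is needed for the effect, a lower number that less compound is needed), compound 1 gives > 25000 nM, which is a limit of the assay and not a number. Compound 3 `Cc1ccc(NC(=O)Nc2cc(C)nc3ccccc23)cc1` differs from compound 1 by hydrogen in place of chloro on an aromatic carbon, with hydrogen in place of chloro on an aromatic carbon, ortho to a methyl group. Among the measured compounds shown here, the only measured guide is an at least 1.0-fold lower number from compound 1 to compound 2 (0.03 log units; that floor lies within the scatter), a swap of chloro in place of methyl on an aromatic carbon. On that basis, no change beyond the scatter is expected in this assay, and no direction can be favoured. The estimated step is a step that the limit leaves unreadable from compound 1 to compound 3. For compound 3 the expected value is 28000 nM, with an estimated range from 12000 nM to 60000 nM.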

Compound 3, half-maximal effective concentration: > 25000 nM
Compound 3 was reported as a limit; the forecaster's own chance of this, stated with the estimate: 65%; the middle value lies beyond the limit too.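

In this assay, among the compounds shown here, compound 1 and compound 3 both stand as limits and not as numbers, so no step between them can be read. On these data alone, whether hydrogen in place of chloro changes the read-out at all remains open.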